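From Compound 2 to Compound 3 in Solubility

The source may report more compounds than this note shows. Statements on the series, on what has been measured and on what is new or still open speak of the compounds shown alone.

Of the compounds shown here, two have been measured so far. Compound 1 `Cn1c(COc2cccc(C(=O)O)c2)nc2ccc(Oc3ccc(Cl)c(F)c3)nc21` gives 1.7 ug/mL in a physicochemical assay for solubility, read by HPLC, measured as thermodynamic solubility, with a stated time of 4 h, at pH 6.8; a lower number here means a less soluble compound, a higher number a more soluble compound. Compound 2 `Cn1c(COc2cccc(C(=O)O)c2)nc2ccc(Oc3cc(Cl)ccn3)cc21` gives 11 ug/mL in this assay, which is the higher of the two numbers, standing a clear margin above compound 1, a gap that lies beyond the scatter of the measurement. The two compounds differ in more than one place, so nothing is said here about what any single part of that difference contributes.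

Compound 3 `Cc1cccnc1Oc1ccc2nc(COc3cccc(C(=O)O)c3)n(C)c2c1` has not yet been measured. It differs from compound 2 in one place: 3-methylpyridin-2-yl in place of 4-chloropyridin-2-yl on an oxygen on an aromatic ring. Within the data shown here, no measured pair in this set shows the effect of such a change, so the expectation rests on compound 2 alone. Among the measured compounds shown here, the change keeps the ring, its single hetero atom and the count of hydrogen-bond acceptors unchanged, and no measured step argues for a large move in either direction. For compound 3 a step no larger than the usual scatter is expected, a 1.3-fold higher number from compound 2 to compound 3 (0.10 log units; within the scatter), and the estimated value in this assay is 14 ug/mL, within a range of 5 ug/mL to 40 ug/mL.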

Compound 3, solubility: 37 ug/mL
The estimate for compound 3 lay 2.6-fold (0.42 log units) below the measured number; the range from low to high includes it.
By their numbers in this assay, from the lowest: compound 1; then compound 2; then compound 3.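

In this assay, among these compounds, the exchange of 4-chloropyridin-2-yl for 3-methylpyridin-2-yl on an oxygen on an aromatic ring gives a 3.4-fold higher number from compound 2 to compound 3 (0.53 log units; beyond the scatter), the only single-place step in this set. The comparison of compound 1 with compound 2 could not assign any difference to one place, whereas this step shows that the group on this oxygen can alone move the number beyond the scatter. That move occurs although the two groups have the same count of heavy atoms and hydrogen-bond acceptors and the same kind of ring, and no measured property is available to explain it.

The change removes the chlorine, adds the methyl and alters where the substituent stands on the ring all at once, so the compounds shown do not separate these contributions; 3-chloropyridin-2-yl and 4-methylpyridin-2-yl would be the groups to tell them apart. They also leave open how a pyridin-2-yl ring without a substituent, or one carrying an amine or a methoxy group, would read in this assay.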